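The source may report more compounds than this note shows. Statements on the series, on what has been measured and on what is new or still open speak of the compounds shown alone.

Going by the values given here, in an ADME assay on L02 cells (Homo sapiens) for antiproliferative activity, read by CCK-8 assay, with a stated time of 6 days (a higher number here means a weaker inhibitor, a lower number a stronger inhibitor), compound 1 `CCN(c1ccc(C#N)c(Cl)c1)c1cc(-c2ccncc2)ccc1C` gives 1730 nM, the only number available, so it cannot yet be ranked against another compound. For compound 2 `N#Cc1ccc(N2CCc3cc(-c4cccnc4)ccc32)cc1C(F)(F)F`, the entry reads "not determined" (no result reported), which offers no comparison. Compound 3 `CCN(c1ccc(C#N)c(Cl)c1)c1cc(-c2ccnn2C)ccc1C` keeps the core of compound 1 and changes one group on an aromatic carbon, para to a methyl group: 1-methyl-1H-pyrazol-5-yl in place of pyridin-4-yl on an aromatic carbon. Here, 1-methyl-1H-pyrazol-5-yl stands in place of pyridin-4-yl. Among the compounds with values here, no measured pair shows what such a swap does in this assay, so no direction is favoured and a change within the usual scatter is expected, although a larger one cannot be excluded. The expected step is a 1.1-fold higher number from compound 1 to compound 3 (0.04 log units; within the scatter). For compound 3, the estimated value is 1900 nM, with an expected range from 650 nM to 5500 nM.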

Compound 3, half-maximal inhibitory concentration: 6230 nM
Beside the measured number, compound 3's estimate is 3.3-fold (0.52 log units) below it; measured number outside the range, above it.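

This aromatic carbon, para to a methyl group, proved sensitive to the group it carries: in this assay, 1-methyl-1H-pyrazol-5-yl in place of pyridin-4-yl gives a 3.6-fold higher number from compound 1 to compound 3 (0.56 log units; beyond the scatter), a modest step towards a weaker inhibitor. The two groups have the same number of heavy atoms and neither carries a net charge, so a swap that leaves those counts unchanged can still move the number beyond the scatter. No measured evidence accounts for the step.

A single pair cannot show whether the higher number belongs to the five-membered ring, its second ring nitrogen or its methyl group. The compounds shown also leave open how this position would respond to an amine or a carboxylic acid in place of these aromatic rings.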